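The compounds below may be only part of what the source reports. "The series", "measured", "known", "first", "only" and "open" are said of these compounds alone.

Measured compounds:
compound 1 `COC(=O)c1sc2cc(C)ccc2c1Nc1cc(OC)c(OC)c(OC)c1` — 20.5 nM
compound 2 `COC(=O)c1sc2ccccc2c1Nc1cc(OC)c(OC)c(OC)c1` — 1540 nM
compound 3 `COC(=O)c1sc2ccc(C)cc2c1Nc1cc(OC)c(OC)c(OC)c1` — 4720 nM

In a functional assay on HL-60 cells (Homo sapiens) for cytotoxicity, read by MTT assay, with a stated time of 72 h (a lower number here means a stronger inhibitor, a higher number a weaker inhibitor), compound 2 gives 1540 nM, the second highest of the three numbers; compound 3 lies nearest with 4720 nM and compound 1 furthest with 20.5 nM. Compound 4 `COC(=O)c1sc2c(C)cccc2c1Nc1cc(OC)c(OC)c(OC)c1` has not been measured. Against compound 2 the change is methyl in place of hydrogen on an aromatic carbon.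

Among the compounds with values here, two measured steps bear on this, both a methyl against a hydrogen on the shared core, each at a different aromatic carbon. The step of a 75-fold higher number from compound 1 to compound 2 (1.88 log units; beyond the scatter) shows a methyl at one position going with a far lower number; the step of a 3.1-fold higher number from compound 2 to compound 3 (0.49 log units; beyond the scatter) shows a methyl at another position going with a higher one. Within the data shown here, the direction therefore depends on where the methyl sits, and no measured compound carries it at the position of compound 4. No step beyond the scatter can be called with confidence in either direction. The number for compound 4 is expected near that of compound 2, with a range wide enough to cover both measured outcomes. Compound 4 is estimated at 1200 nM, between 100 nM and 8000 nM. The step expected is a 1.3-fold lower number from compound 2 to compound 4 (0.11 log units; within the scatter).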

Compound 4, half-maximal inhibitory concentration: 4270 nM
Estimate against measurement, compound 4: 3.6-fold (0.55 log units) below; measured number inside the range.
By their numbers in this assay, from the lowest: compound 1; then compound 2; then compounds 4 and 3 (each within the scatter of the next).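

In this assay, methyl in place of hydrogen on the aromatic carbon ortho to a fused ring and meta to a fused ring gives a 2.8-fold higher number from compound 2 to compound 4 (0.44 log units; beyond the scatter), so this position does not share the gain linked to the methyl of compound 1, seen in a 75-fold higher number from compound 1 to compound 2 (1.88 log units; beyond the scatter). The step runs in the same direction as a 3.1-fold higher number from compound 2 to compound 3 (0.49 log units; beyond the scatter), so two of the three methyl placements go with a higher number, and compound 1 goes against that. Nothing at hand bears on why the placements differ.

As far as these compounds go, whether a chlorine atom, a methoxy group or a longer chain on this carbon would follow the methyl remains open. Also open, from the compounds shown here alone, is whether an amine on the same carbon would go with a higher or a lower number.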